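This account rests on a few compounds, and the source may have more. Where it says the series, first, only, none or still open, it means among the compounds named here.

In a functional assay on HCT-116 cells (Homo sapiens) for antiproliferative activity, read by radiometric assay, with a stated time of 72 h (a lower number here means a stronger inhibitor, a higher number a weaker inhibitor), compound 1 `Cc1cc(F)ccc1Nc1ncnc2cc(NC(=O)CCCCCCC(=O)NO)sc12` gives 2640 nM and compound 2 `COc1ccc(Nc2ncnc3cc(NC(=O)CCCCCCC(=O)NO)sc23)c(C)c1` gives 2480 nM. Among the measured compounds shown here, these are the only two numbers so far, and they sit level with each other. Methoxy in place of fluoro on an aromatic carbon amounts to a 1.1-fold lower number from compound 1 to compound 2 (0.03 log units; within the scatter). Compound 3 `CCc1ccc(Nc2ncnc3cc(NC(=O)CCCCCCC(=O)NO)sc23)cc1` brings a different change: 4-ethylphenyl in place of 4-methoxy-2-methylphenyl on a nitrogen on an aromatic ring. In words, this is 4-ethylphenyl in place of 4-methoxy-2-methylphenyl on a nitrogen on an aromatic ring. For the measured compounds named here, only the step to compound 2, a 1.1-fold lower number from compound 1 to compound 2 (0.03 log units; within the scatter), bears on this, and only loosely, as it altered a single group. Going by the values given here, no measured pair shows what ethyl does here, so the direction stays open and the range must be wide. The expected change is no more than scatter, an estimated 1.1-fold lower number from compound 2 to compound 3 (0.05 log units; within the scatter). For compound 3 the estimated value is 2200 nM, with an expected range of 700 nM to 6500 nM.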

Compound 3, half-maximal inhibitory concentration: 2360 nM
The estimate for compound 3 lay 1.1-fold (0.03 log units) below the measured number; low and high end bracket the measured number.
By their numbers in this assay, from the lowest: compounds 3, 2 and 1 (each within the scatter of the next).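

In this assay, the change at this nitrogen on an aromatic ring is larger than the earlier single-group swap, yet it gives a 1.1-fold lower number from compound 2 to compound 3 (0.02 log units; within the scatter). Starting from the fluoro compound, 4-ethylphenyl in place of 4-fluoro-2-methylphenyl gives a 1.1-fold lower number from compound 1 to compound 3 (0.05 log units; within the scatter). So all three aryl groups sit level here, even though the 2-methyl group is gone and the oxygen of the methoxy has left, and no supporting data are available to account for this.

As far as these compounds go, whether an amine or a carboxylic acid on this phenyl ring, or a longer chain in place of ethyl, would move the number beyond the scatter stays open. The shared core and the hydroxamic acid chain are identical in all three compounds, so these results say nothing about those parts.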